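The source may hold more compounds than are shown below. What is called first, only, known or untested is meant among the compounds shown, and "the series" means these compounds.

Measured so far:
- compound 1, `O=C1[C@@H](NS(=O)(=O)c2ccc(-c3ccccn3)s2)CCN1Cc1cc2[nH]cccc-2n1`: 8%
- compound 2, `O=C1[C@@H](NS(=O)(=O)c2ccc(-c3ccncc3)s2)CCN1Cc1cc2[nH]cccc-2n1`: 35%
- compound 3, `O=C1[C@@H](NS(=O)(=O)c2ccc(-c3ccncc3)s2)CCN1Cc1cc2cc[nH]cc-2n1`: 50%

In an assay on isolated protein for inhibition of coagulation factor X (Oryctolagus cuniculus), tested at 1 uM (on this read-out lower numbers stand for less inhibition and higher numbers for more inhibition at the one concentration tested (going by the name of the read-out)), compound 2 stands second highest of the three numbers; compound 3 lies a number 15 percentage points higher from compound 2 to compound 3 (beyond the scatter), and compound 1 lies a number 27 percentage points higher from compound 1 to compound 2 (beyond the scatter) below it.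

Compound 4, `O=C1[C@@H](NS(=O)(=O)c2ccc(-c3ccon3)s2)CCN1Cc1cc2[nH]cccc-2n1`, differs from compound 2 at the group on the thiophene-type ring: 1,2-oxazol-3-yl in place of pyridin-4-yl on an aromatic carbon. Within the data shown here, the one measured step that bears on this position is the change from compound 1 to compound 2, a number 27 percentage points higher from compound 1 to compound 2 (beyond the scatter), which shows that the group on this aromatic carbon moves the read-out in this assay by a modest amount. Among the measured compounds shown here, no measured step swaps a six-membered ring for a five-membered one here, so the direction is not fixed by the data; a modest drop from compound 2 is expected, since the group leaving is the one that gave the better of the two measured variants at this site.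

For compound 4 the expected step is a number 15 percentage points lower from compound 2 to compound 4 (beyond the scatter) in this assay, an estimate of 20% with a range from 5% to 45%.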

Compound 4, a percentage reported as inhibition, at one concentration (the size of the read-out at that concentration, not a potency): 31%
The estimate for compound 4 lay 11 percentage points below the measured number, and the stated range covers the measured number.
By their numbers in this assay, from the lowest: compound 1; then compounds 4 and 2 (each within the scatter of the next); then compound 3.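

In this assay, a six-membered ring is not needed on this aromatic carbon: 1,2-oxazol-3-yl and pyridin-4-yl read alike, with a number 4 percentage points lower from compound 2 to compound 4 (within the scatter). The same five-membered group stands clear of pyridin-2-yl, with a number 23 percentage points higher from compound 1 to compound 4 (beyond the scatter), so among the three groups at this place only pyridin-2-yl sits apart, and ring size alone does not account for the read-out. Nothing available explains why these groups compare as they do.

Among these compounds, it remains open whether 1,2-oxazol-3-yl keeps its standing relative to pyridin-4-yl on the core of compound 3, where the only example so far carries pyridin-4-yl. On these data alone, it is equally open how a non-aromatic group at this place, such as a primary amine or a carboxylic acid, would read.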